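Arylethoxy-imidazoline series: pyridyl replacement of the distal ring

The compounds below may be only part of what the source reports. "The series", "measured", "known", "first", "only" and "open" are said of these compounds alone.

Measured compounds:
Compound 1 `Cc1ccccc1-c1ccccc1OC(C)C1=NCCN1`; in a functional assay on CHO cells for agonist activity at Alpha-2B adrenergic receptor (Homo sapiens) (a lower number here means a smaller maximal response, a higher number a larger maximal response), compound 1 gives < 0.3, which is a limit of the assay and not a number.
Compound 2 `Cc1ccc(-c2ccccc2OC(C)C2=NCCN2)cc1`; in this assay compound 2 gives < 0.3, again a limit rather than a number.

Among the compounds with values here, compound 2 stands only at a limit in this assay; the one further value shown, for compound 1, is also a limit, so the step that the two limits leave unreadable from compound 1 to compound 2 cannot be sized. Both values sit at the same point, (the limit of < 0.3 in this assay, at which 2 of the 2 values shown sit).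

Compound 3 `CC(Oc1ccccc1-c1ccncc1)C1=NCCN1` is not yet measured. It differs from compound 2 in one place: pyridin-4-yl in place of 4-methylphenyl on an aromatic carbon. Within the data shown here, no measured step bears directly on this change, and the one step available is unreadable. On that basis compound 3 is expected to remain at or near the limit in this assay, with 0.2 and a range of 0.05 to 0.45. The step that the limit leaves unreadable from compound 2 to compound 3 is therefore estimated to lie within the scatter.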

Compound 3, intrinsic activity: the largest response reached, as a fraction of the reference agonist's: < 0.3
Compound 3: no number, only a limit; the forecaster's own chance of this, stated with the estimate: 70%; the middle value lies beyond the limit too.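

In this assay, within the data shown here, compound 3 gives < 0.3 as a limit and not a number, so no step from compound 1 or compound 2 to it can be read: the limit of < 0.3 in this assay, at which 3 of the 3 values shown sit.

Open, as far as these compounds go, is how 2-methylphenyl, 4-methylphenyl and pyridin-4-yl compare in maximal response, and whether any of them reaches a readable value.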